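This account rests on a few compounds, and the source may have more. Where it says the series, first, only, none or still open, it means among the compounds named here.

Measured compounds:
compound 1 `CC(=O)OC/C(=C\c1ccc(Cl)cc1Cl)C(=O)c1ccc(Cl)cc1` gives 8100 nM
compound 2 `CC(=O)OC/C(=C/c1ccc(Cl)cc1Cl)C(=O)c1ccccc1` gives 19000 nM
compound 3 `CC(=O)OC/C(=C/c1ccc(Cl)cc1)C(=O)c1ccc(Cl)cc1` gives 17000 nM

In a functional assay on WiDr cells (Homo sapiens) for inhibition, read by sulforhodamine B assay, with a stated time of 48 h (a higher number here means a weaker inhibitor of growth, a lower number a stronger inhibitor of growth), compound 3 stands second highest of the three numbers. Its nearest neighbour is compound 2, whose number lies within the scatter of that of compound 3, so no order between them can be read. Compound 1 gives the lowest number of the three, a gap to compound 3 that lies beyond the scatter.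

Compound 4 `CC(=O)OC/C(=C/c1ccc(Cl)cc1Cl)C(=O)c1ccc(Cl)cc1` is not yet measured. It differs from compound 3 by chloro in place of hydrogen on an aromatic carbon. Among the measured compounds shown here, with no measured step of this kind to lean on, a modest step down in this assay is expected, a 1.7-fold lower number from compound 3 to compound 4 (0.23 log units; within the scatter). Compound 4 is therefore estimated at 10000 nM, within a range of 4000 nM to 25000 nM.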

Compound 4, concentration for 50% growth inhibition: 20000 nM
For compound 4 the middle estimate is 2.0-fold (0.30 log units) below the measured one; measured number inside the range.
By their numbers in this assay, from the lowest: compound 1; then compounds 3, 2 and 4 (each within the scatter of the next).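

Chloro in place of hydrogen on an aromatic carbon, ortho to a large group, gives no readable change in this assay (a 1.2-fold higher number from compound 3 to compound 4 (0.07 log units; within the scatter)). The same exchange elsewhere on the molecule gives none either (a 1.1-fold higher number from compound 2 to compound 4 (0.02 log units; within the scatter)). Among the compounds shown here, the only step beyond the scatter is the one between the two double-bond forms (a 2.5-fold higher number from compound 1 to compound 4 (0.39 log units; beyond the scatter)), and it can be tied to the double bond because of this: the fact that compounds 1 and 4 differ only in the configuration as drawn.

On these data alone, whether a methoxy group or an amine at this place would shift the number remains open, as does whether the gap between double-bond forms holds with other ring substituents.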